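This account rests on a few compounds, and the source may have more. Where it says the series, first, only, none or still open, it means among the compounds named here.

Measured compounds in an ADME assay on the whole organism (Mus musculus, strain BALB/C) for pharmacokinetics, read by LC-MS, with a stated time of 24 h, at a dose of 1 mg/kg by the intravenous route; on this read-out higher numbers stand for fast clearance and lower numbers for slow clearance:
compound 1 `C[C@H](Nc1nc(N)nc(N)c1C#N)c1cc2ccc(F)cn2c(=O)c1-c1ccccc1`: 25 mL/min/kg
compound 2 `C[C@H](Nc1nc(N)nc(N)c1C#N)c1cc(=O)n2cc(F)ccc2c1-c1cc(F)cc(F)c1`: 18 mL/min/kg
compound 3 `Cc1c([C@H](C)Nc2nc(N)nc(N)c2C#N)c(-c2ccccc2)c(=O)n2cc(F)ccc12`: 49 mL/min/kg

Compound 1 sits among the three numbers with compound 2 and compound 3 on either side; the gap to each is within the scatter, so no order among the three can be claimed. For the measured compounds named here, compound 2 differs from compound 1 in more than one place and no single step is drawn between them.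

Compound 4 `C[C@H](Nc1nc(N)nc(N)c1C#N)c1c(-c2ccccc2)c(=O)n2cc(F)ccc2c1C1CC1` is the next member to go into this assay. It differs from compound 1 in one place: cyclopropyl in place of hydrogen on an aromatic carbon.

Going by the values given here, one measured step bears on this change. The step of a 2.0-fold higher number from compound 1 to compound 3 (0.29 log units; within the scatter) puts a methyl on the same aromatic carbon of the shared core and stays within the scatter. Among the compounds with values here, the cyclopropyl entering in compound 4 is a larger group at that carbon, and no measured compound carries it, so the methyl step is the only guide.

The expectation for compound 4 is therefore a step of about a 1.6-fold higher number from compound 1 to compound 4 (0.20 log units; within the scatter) from compound 1, in the direction of a higher number, of a size that may or may not clear the scatter. Compound 4 is estimated at 40 mL/min/kg, with a range from 20 mL/min/kg to 80 mL/min/kg.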

Compound 4, clearance: 24 mL/min/kg
Beside the measured number, compound 4's estimate is 1.7-fold (0.22 log units) above it; the range from low to high includes it.
By their numbers in this assay, from the lowest: compounds 2, 4, 1 and 3 (each within the scatter of the next, the first and the last beyond it).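

In this assay the step of a 1.0-fold lower number from compound 1 to compound 4 (0.02 log units; within the scatter) shows that cyclopropyl in place of hydrogen on this aromatic carbon leaves clearance without a readable shift, so this position carries a three-membered ring of carbon with no separation from the unsubstituted compound. For the compounds shown here, the step of a 2.0-fold lower number from compound 3 to compound 4 (0.31 log units; beyond the scatter) is the first at this carbon to clear the scatter, though only modestly, while the step of a 2.0-fold higher number from compound 1 to compound 3 (0.29 log units; within the scatter) stays within it, so methyl and cyclopropyl can be told apart from each other but neither can be told apart from hydrogen. No measured data bear on what lies behind this gap between the two groups.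

The compounds shown leave open whether the gap between methyl and cyclopropyl is more than a single modest pair, and an ethyl or isopropyl group at this carbon would test that. They also leave open how clearance responds when this carbon carries a group containing a heteroatom, such as an amine, a methoxy group or a carboxylic acid, since only groups of carbon and hydrogen appear here.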